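Ester Swap from Ethyl to Cyclohexyl in Compound 4

The source may hold more compounds than are shown below. What is called first, only, known or untested is meant among the compounds shown, and "the series" means these compounds.

Measured so far in a functional assay on the whole organism (strain CD1) for inhibition, with Mus musculus as the target, with stated times of 15 min and 20 min, at a dose of 10 mg/kg by the subcutaneous route; on this read-out lower numbers stand for less inhibition and higher numbers for more inhibition at the one dose given (going by the name of the read-out):
Compound 1, `N#C/C(=C\c1ccccc1)C(=O)OC1CCCCC1`: compound 1 gives 7.1%
Compound 2, `N#C/C(=C\c1ccc[nH]1)C(=O)OC1CCCCC1`: compound 2 gives 10%
Compound 3, `CCOC(=O)/C(C#N)=C/c1c[nH]cn1`: compound 3 gives 33%

Compound 3 stands highest of the three numbers in this assay. Its nearest neighbour is compound 2, whose value is lower by a gap that lies beyond the scatter, and compound 1 lies further below still, also beyond the scatter. The one measured step among these compounds, a number 2.9 percentage points higher from compound 1 to compound 2 (within the scatter), concerns a change at the double-bonded chain carbon, 1H-pyrrol-2-yl in place of phenyl, and is within the scatter.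

Compound 4, `N#C/C(=C\c1c[nH]cn1)C(=O)OC1CCCCC1`, arises from compound 3 by the change (cyclohexyl in place of ethyl on an oxygen next to a carbonyl group). Among the measured compounds shown here, no measured step concerns this part of the molecule: compounds 1 and 2 both carry the cyclohexyl ester, compound 3 the ethyl ester, and the two sets differ as well in the group on the double-bonded chain carbon, so the numbers cannot separate the two changes. The step of a number 2.9 percentage points higher from compound 1 to compound 2 (within the scatter) does not bear on the ester. The estimate for compound 4 therefore rests mainly on compound 3, whose value 33% is the starting point, with a wide range and an expected step of a number 5 percentage points lower from compound 3 to compound 4 (within the scatter), none beyond the scatter in either direction. Compound 4 is estimated at 28%, between 8% and 48%.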

Compound 4, a percentage reported as inhibition, in the whole organism at one dose (the size of the read-out at that dose, not a potency): 50%
Compound 4: the middle estimate sits 22 percentage points below what was measured, and the stated range ends below it.
By their numbers in this assay, from the lowest: compounds 1 and 2 (each within the scatter of the next); then compound 3; then compound 4.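

In this assay, the ester position now has a reading of its own: with the 1H-imidazol-4-yl group held fixed, cyclohexyl in place of ethyl on an oxygen next to a carbonyl group gives a number 17 percentage points higher from compound 3 to compound 4 (beyond the scatter). With the cyclohexyl ester held fixed, the group on the double-bonded chain carbon also proves to matter, although phenyl and 1H-pyrrol-2-yl had stayed within the scatter of each other: 1H-imidazol-4-yl in place of 1H-pyrrol-2-yl gives a number 40 percentage points higher from compound 2 to compound 4 (beyond the scatter), and 1H-imidazol-4-yl in place of phenyl gives a number 42.9 percentage points higher from compound 1 to compound 4 (beyond the scatter). No supporting data are available to account for any of these steps.

From the compounds shown here alone, whether the gain from cyclohexyl over ethyl carries over to the phenyl or 1H-pyrrol-2-yl compounds remains open, as the ester change has been read only with 1H-imidazol-4-yl in place. Also open, going by these compounds, is how this read-out would respond at the same position to a cyclopentyl ester, a longer chain such as n-hexyl, or a free carboxylic acid, and whether the order of the compounds would hold at other doses.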